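This account rests on a few compounds, and the source may have more. Where it says the series, first, only, none or still open, it means among the compounds named here.

Compound 1 `Cc1cc(Nc2cc(-c3ccccc3)[nH]n2)n2nc(SCc3ccc(Cl)cc3)nc2n1`; compound 2 `Cc1nc2nc(SCc3ccc(Cl)cc3)nn2c(Nc2cc(-c3ccccc3)[nH]n2)c1C`; compound 3 `Cc1cc(Nc2ccn(Cc3ccccc3)n2)n2nc(SCc3ccc(Br)cc3)nc2n1`.

In a functional assay on PC-9 cells (Homo sapiens) for inhibition, read by MTT assay, with a stated time of 72 h (a lower number here means a stronger inhibitor, a higher number a weaker inhibitor), compound 1 gives 6710 nM. Compound 2 reaches only the limit > 50000 nM in this assay. Compound 3 likewise reaches only the limit > 50000 nM. Among the measured compounds shown here, compound 1 thus holds the only number among the three; the limit of > 50000 nM in this assay, at which 2 of the 3 values shown sit, marks where the other two sit. For the measured compounds named here, the one step with a single change, an at least 7.4-fold higher number from compound 1 to compound 2 (0.87 log units; beyond the scatter), concerns methyl in place of hydrogen on an aromatic carbon. Compound 4 `COc1ccc(CSc2nc3nc(C)cc(Nc4cc(-c5ccccc5)[nH]n4)n3n2)cc1` differs from compound 1 by methoxy in place of chloro on an aromatic carbon. Going by the values given here, no measured step touches this exchange, so no shift beyond the scatter is expected. For compound 4 the expected step is a 1.2-fold higher number from compound 1 to compound 4 (0.08 log units; within the scatter). Compound 4 is estimated at 8000 nM, between 2500 nM and 30000 nM.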

Compound 4, half-maximal inhibitory concentration: 8110 nM
For compound 4 the middle estimate is 1.0-fold (0.01 log units) below the measured one; the range from low to high includes it.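

The exchange of 4-chlorobenzyl for 4-methoxybenzyl gives a 1.2-fold higher number from compound 1 to compound 4 (0.08 log units; within the scatter), so this para position accepts either chloro or methoxy in this assay, at least for this pair. The methyl step on the core is different, giving an at least 7.4-fold higher number from compound 1 to compound 2 (0.87 log units; beyond the scatter). Compound 4 keeps a measured number and does not join the compounds held at an assay limit: the limit of > 50000 nM in this assay, at which 2 of the 4 values shown sit.

As far as these compounds go, whether an amine or a carboxylic acid at this para position would keep activity stays open. So does the effect of a longer chain in place of methoxy.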